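Benzyl ester in the prolinamide series: compound 4

The compounds below may be only part of what the source reports. "The series", "measured", "known", "first", "only" and "open" are said of these compounds alone.

Compound 1 `O=C1CC[C@@H](COC(=O)c2ccsc2NC(=O)[C@@H]2CCCN2)N1` is one of three measured members of the series. In a functional assay on MCF7 cells (Homo sapiens) for inhibition (on this read-out lower numbers stand for stronger inhibition of growth and higher numbers for weaker inhibition of growth), compound 1 gives 148 ug/mL, which stands second highest of three numbers, all of them within the scatter of one another. Compound 3 `COC(=O)c1sccc1NC(=O)[C@@H]1CCCN1` gives 163 ug/mL in this assay, the number nearest to compound 1. Among the measured compounds shown here, compound 2 `O=C(OCC(F)(F)F)c1ccsc1NC(=O)[C@@H]1CCCN1` gives 89.7 ug/mL, the number furthest from compound 1, and the one step measured between two compounds differing in a single place, a 1.6-fold lower number from compound 1 to compound 2 (0.22 log units; within the scatter), lies within the scatter.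

Compound 4 `O=C(OCc1ccccc1)c1ccsc1NC(=O)[C@@H]1CCCN1` is not yet measured in this assay. It differs from compound 1 as follows: phenyl in place of 5-oxopyrrolidin-2-yl on a saturated chain carbon bound to an oxygen next to a carbonyl group. For the measured compounds named here, the only comparable step, a 1.6-fold lower number from compound 1 to compound 2 (0.22 log units; within the scatter), changed the same position and produced no movement beyond the scatter, so a similar outcome is expected here; the three measured numbers themselves span less than the scatter. Going by the values given here, no measured pair addresses the phenyl group entering, so the direction cannot be anticipated from these data.

Compound 4 is therefore expected to give about 120 ug/mL in this assay, within a range of 55 ug/mL to 260 ug/mL. The step of a 1.2-fold lower number from compound 1 to compound 4 (0.09 log units; within the scatter) is estimated to stay within the scatter.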

Compound 4, concentration for 50% growth inhibition: > 250 ug/mL
Compound 4: only a limit was reported (the forecaster's own chance of this, stated with the estimate: 10%); middle value at least 2.0-fold (0.31 log units) from the limit.
By their numbers in this assay, from the lowest: compounds 2, 1 and 3 (each within the scatter of the next). At a limit, above all of these: compound 4.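

The reading for compound 4 in this assay is a limit of the assay and not a number: the limit of > 250 ug/mL in this assay, at which 1 of the 4 values shown sits. Even so, this position now shows a step beyond the scatter, which the earlier pair did not: with phenyl in place of trifluoromethyl on the saturated chain carbon bound to an oxygen next to a carbonyl group, the data give an at least 2.7-fold higher number from compound 2 to compound 4 (0.44 log units; beyond the scatter), so growth inhibition is weaker with the benzyl ester than with the trifluoroethyl ester of compound 2. The exchange of (5-oxopyrrolidin-2-yl)methyl for benzyl gives an at least 1.6-fold higher number from compound 1 to compound 4 (0.22 log units; that floor lies within the scatter), and since that floor lies within the scatter, the pair shows no certain separation, though the true gap could be larger.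

Open, from the compounds shown here alone, is how far compound 4 lies beyond the limit, and so how large either step really is. Also open, going by these compounds, is whether the weaker inhibition follows the phenyl ring as such, a question that a cyclohexyl or pyridyl group in its place, or a phenylethyl ester, would address.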